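The source may hold more compounds than are shown below. What is called first, only, known or untested is meant among the compounds shown, and "the series" means these compounds.

Of the compounds shown here, three that share one core have been tested in a functional assay on CCRF-CEM cells (Homo sapiens) for antiproliferative activity; on this read-out lower numbers stand for stronger inhibition and higher numbers for weaker inhibition. Compound 1 `COc1cc(C(=O)c2sc(-c3ccc(-c4ccccc4)cc3)cc2N)cc(OC)c1OC` gives only a limit of the assay in this assay, > 10000 nM. Compound 2 `COc1cc(C(=O)c2sc(-c3ccc(Br)cc3)cc2N)cc(OC)c1OC` gives 86 nM in this assay. Compound 3 `COc1ccc(-c2cc(N)c(C(=O)c3cc(OC)c(OC)c(OC)c3)s2)cc1OC` gives 20 nM in this assay, the lowest of the two definite numbers; its nearest neighbour is compound 2, and between them there is a 4.3-fold lower number from compound 2 to compound 3 (0.63 log units; beyond the scatter). Between the first two compounds, bromo in place of phenyl on an aromatic carbon brought an at least 110-fold lower number from compound 1 to compound 2 (2.06 log units; beyond the scatter).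

Compound 4 `COc1cc(C(=O)c2sc(-c3ccc(Cl)cc3)cc2N)cc(OC)c1OC` has not yet been measured. It differs from compound 3 at one position: 4-chlorophenyl in place of 3,4-dimethoxyphenyl on an aromatic carbon. Both measured steps bear on this change. The step of an at least 110-fold lower number from compound 1 to compound 2 (2.06 log units; beyond the scatter) shows how much a bromo group at this place lowers the number compared with a phenyl, and a 4.3-fold lower number from compound 2 to compound 3 (0.63 log units; beyond the scatter) shows that 4-bromophenyl sits somewhat higher than 3,4-dimethoxyphenyl. A 4-chlorophenyl resembles 4-bromophenyl far more than 3,4-dimethoxyphenyl, so compound 4 is expected to land close to compound 2, a modest rise relative to compound 3. The expected step is therefore a 4.0-fold higher number from compound 3 to compound 4 (0.60 log units; beyond the scatter). Compound 4 is thus estimated at 80 nM, with a likely range from 25 nM to 250 nM.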

Compound 4, half-maximal inhibitory concentration: 70 nM
The estimate for compound 4 lay 1.1-fold (0.06 log units) above the measured number, within the range that was stated.
By their numbers in this assay, from the lowest: compound 3; then compounds 4 and 2 (each within the scatter of the next). At a limit, above all of these: compound 1.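

At this place on the shared core, in this assay the change from bromo to chloro gives a 1.2-fold lower number from compound 2 to compound 4 (0.09 log units; within the scatter) and so leaves these two halogens on the phenyl ring indistinguishable. The edge of 3,4-dimethoxyphenyl now holds against a second halogen-bearing phenyl, with a 3.5-fold higher number from compound 3 to compound 4 (0.54 log units; beyond the scatter) in the change to 4-chlorophenyl, so the gap seen earlier is not peculiar to bromo. The large difference from a terminal phenyl also returns with chloro, as an at least 140-fold lower number from compound 1 to compound 4 (2.15 log units; beyond the scatter) shows, and this size is only a bound since compound 1 stands at a limit of the assay: the limit of > 10000 nM in this assay, at which 1 of the 4 values shown sits.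

The compounds shown do not separate the contributions of the two methoxy groups, and a phenyl ring carrying a single methoxy group would be needed to tell whether one alone accounts for the edge of compound 3. They also leave open how a smaller halogen such as fluoro, or a phenyl ring bearing an amine or a carboxylic acid, would fare at this place.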